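The compounds below may be only part of what the source reports. "The series", "measured", "known", "first", "only" and "open" are said of these compounds alone.

Measured compounds:
- Compound 1 `COc1cc(OC)c2c(=O)cc(/C=C/c3ccc([N+](=O)[O-])cc3)oc2c1`: > 40000 nM
- Compound 2 `COc1cc(OC)c2c(=O)cc(/C=C/c3ccc(C(F)(F)F)cc3)oc2c1`: > 40000 nM
- Compound 3 `COc1cc(OC)c2c(=O)cc(/C=C/c3ccc(Br)cc3)oc2c1`: > 40000 nM

In a functional assay on PC-3 cells (Homo sapiens) for antiproliferative activity, read by MTT assay, with a stated time of 12 h (on this read-out lower numbers stand for stronger inhibition and higher numbers for weaker inhibition), compound 1 gives only a limit, > 40000 nM. Compound 2 likewise gives only a limit in this assay, > 40000 nM. Compound 3 also gives only a limit in this assay, > 40000 nM. All three values therefore sit at the limit of > 40000 nM in this assay, at which 3 of the 3 values shown sit, so none of the three can be placed against the others: a step that the two limits leave unreadable from compound 1 to compound 2, a step that the two limits leave unreadable from compound 1 to compound 3 and a step that the two limits leave unreadable from compound 2 to compound 3 are each of unreadable size.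

Compound 4 `COc1cc(OC)c2c(=O)cc(/C=C/c3ccc(OC(F)(F)F)cc3)oc2c1` is not yet measured in this assay. It differs from compound 1 by trifluoromethoxy in place of nitro on an aromatic carbon. The three measured steps on the shared core all exchange one group on that aromatic carbon and all stay at the limit, so they bear on this change only in showing no movement that the assay could resolve. The expected step that the limit leaves unreadable from compound 1 to compound 4 is therefore one that most likely again ends at the limit. Compound 4 is estimated to give 60000 nM in this assay, within 20000 nM to 200000 nM.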

Compound 4, half-maximal inhibitory concentration: > 40000 nM
Compound 4 ended at the assay's limit (the forecaster's own chance of this, stated with the estimate: 80%); the middle value lies beyond the limit too.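

Compound 4 stays at a limit of this assay and not at a number, so its steps from compound 1, compound 2 and compound 3 cannot be read: the limit of > 40000 nM in this assay, at which 4 of the 4 values shown sit.

The compounds shown leave open how these four rank against one another, and whether any group at this place gives a measurable value.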